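Aryl swaps on the fused core: thiophen-2-yl variant

The source may report more compounds than this note shows. Statements on the series, on what has been measured and on what is new or still open speak of the compounds shown alone.

Measured in a functional assay on KB cells (Homo sapiens) for inhibition, with a stated time of 72 h (a higher number here means a weaker inhibitor, a lower number a stronger inhibitor), so far:
compound 1 `COc1ccc(S(=O)(=O)N2CCc3cccc(-c4ccc([N+](=O)[O-])cc4)c32)cc1`: 52.5 nM
compound 2 `COc1ccc(S(=O)(=O)N2CCc3cccc(-c4ccc(F)cc4)c32)cc1`: 86 nM
compound 3 `COc1ccc(S(=O)(=O)N2CCc3cccc(-c4ccncc4)c32)cc1`: 96 nM

All three values lie within the scatter of one another: a 1.6-fold higher number from compound 1 to compound 2 (0.21 log units; within the scatter), a 1.1-fold higher number from compound 2 to compound 3 (0.05 log units; within the scatter) and a 1.8-fold higher number from compound 1 to compound 3 (0.26 log units; within the scatter). Compound 2 thus sits among three numbers that the assay cannot tell apart.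

Compound 4 `COc1ccc(S(=O)(=O)N2CCc3cccc(-c4cccs4)c32)cc1` differs from compound 2 by thiophen-2-yl in place of 4-fluorophenyl on an aromatic carbon. Every step seen so far exchanges the aromatic group at this same carbon of the shared core, and none of them moved beyond the scatter. The change to thiophen-2-yl is another exchange of that kind, so in this assay no step beyond the scatter is expected: a 1.0-fold higher number from compound 2 to compound 4 (0.02 log units; within the scatter). Compound 4 is therefore estimated at 90 nM, with a range from 45 nM to 180 nM.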

Compound 4, half-maximal inhibitory concentration: 215 nM
The estimate for compound 4 lay 2.4-fold (0.38 log units) below the measured number; measured number above the stated range.
By their numbers in this assay, from the lowest: compounds 1, 2 and 3 (each within the scatter of the next); then compound 4.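

In this assay, the aromatic group at this carbon of the shared core can shift the number beyond the scatter: thiophen-2-yl stands apart from all three earlier groups (a 2.5-fold higher number from compound 2 to compound 4 (0.40 log units; beyond the scatter); a 2.2-fold higher number from compound 3 to compound 4 (0.35 log units; beyond the scatter); a 4.1-fold higher number from compound 1 to compound 4 (0.61 log units; beyond the scatter)). The three six-membered aromatic groups remain within the scatter of one another, so this separation rests on a single five-membered example. No available measurement accounts for the step.

As far as these compounds go, whether the step comes from the five-membered ring as such or belongs to thiophen-2-yl alone stays open. Also open, from the compounds shown here alone, is how an amine or a carboxylic acid on the phenyl group would read in this assay.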